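A few compounds are considered here, and "the series" means these few. Any claim that something is new, unique, unknown or untested is made for them only; others in the source may bear on it.

Working notes on the series.

Among the measured compounds shown here, compound 2 `Cc1cc(Nc2cc(-c3ccccc3)[nH]n2)n2nc(SCc3csc4ccccc34)nc2n1` gives 2280 nM in a functional assay on MGC-803 cells (Homo sapiens) for inhibition, read by MTT assay, with a stated time of 72 h (a higher number here means a weaker inhibitor, a lower number a stronger inhibitor), the lowest of the three numbers so far. Compound 1 `Cc1cc(Nc2cc(-c3ccccc3)[nH]n2)n2ncnc2n1` carries hydrogen where compound 2 carries ((1-benzothiophen-3-yl)methyl)sulfanyl. In this assay, for the measured compounds named here, compound 1 gives 21700 nM, and the step of a 9.5-fold lower number from compound 1 to compound 2 (0.98 log units; beyond the scatter) is the one measured change in this set. Compound 3 `CCCCCc1c(C)nc2nc(SCc3ccc(Cl)cc3)nn2c1Nc1cc(-c2ccccc2)[nH]n1` differs from compound 2 at several places. In this assay compound 3 gives 7140 nM; its number sits between those of compound 1 and compound 2.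

Compound 4 `Cc1cc(Nc2cc(-c3ccccc3)[nH]n2)n2nc(SCCc3ccccc3)nc2n1` is the next candidate. The change from compound 2 is benzyl in place of 1-benzothiophen-3-yl on a saturated chain carbon bound to a sulfur. The sulfur-linked arylalkyl group is kept, so the step of a 9.5-fold lower number from compound 1 to compound 2 (0.98 log units; beyond the scatter) bears on it only insofar as it shows that this kind of group, as a whole, moves the number away from that of compound 1. Going by the values given here, no measured step probes the aryl part itself, so the size of the step from compound 2 to compound 4 cannot be read from the data; a change within or just beyond the scatter, in either direction, is the working assumption, leaning slightly toward a higher number. Compound 4 is therefore expected at 3500 nM in this assay, with a range of 1500 nM to 9000 nM, which means an expected step of a 1.5-fold higher number from compound 2 to compound 4 (0.19 log units; within the scatter).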

Compound 4, half-maximal inhibitory concentration: 5620 nM
Compound 4: the middle estimate sits 1.6-fold (0.21 log units) below what was measured; the measured number falls inside the stated range.
By their numbers in this assay, from the lowest: compound 2; then compounds 4 and 3 (each within the scatter of the next); then compound 1.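

In this assay, benzyl in place of 1-benzothiophen-3-yl on a saturated chain carbon bound to a sulfur gives a 2.5-fold higher number from compound 2 to compound 4 (0.39 log units; beyond the scatter), so the number depends on what the sulfur-linked group carries and not only on that group being present. Phenethylsulfanyl in place of hydrogen on an aromatic carbon still gives a 3.9-fold lower number from compound 1 to compound 4 (0.59 log units; beyond the scatter), so in both compound 2 and compound 4 a sulfur-linked arylalkyl group lowers the number relative to compound 1, with the smaller drop for phenethylsulfanyl. Nothing at hand gives a reason for the gap between these two groups.

The same difference also reads as (1-benzothiophen-3-yl)methyl to phenethyl, so the compounds shown cannot separate the contribution of the aromatic ring system from that of the link joining it to the sulfur. From the compounds shown here alone, it also remains open how the number would respond to benzylsulfanyl, to a longer chain ending in phenyl, or to an amine or a carboxylic acid on the phenyl ring of the phenethyl group.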